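The source may report more compounds than this note shows. Statements on the series, on what has been measured and on what is new or still open speak of the compounds shown alone.

The shared core of compound 1 `Cc1ncccc1OC[C@@H]1CCCN1C` appears in every compound of the set, with changes only on the six-membered aromatic ring with one nitrogen. In an assay on K177 cells for activation of Neuronal acetylcholine receptor; alpha4/beta2 (Homo sapiens) (a higher number here means that more compound is needed for the effect, a lower number that less compound is needed), compound 1 gives 4800 nM. Compound 2 `CN1CCC[C@H]1COc1cnccc1Br` also bears a bromo group; in this assay compound 2 reaches only a limit of the assay, > 1000000 nM, and no number is obtained for it. Compound 3 `CN1CCC[C@H]1COc1cncc(Br)c1` likewise bears a bromo group, and in this assay compound 3 gives 5950 nM, the higher of the two numbers obtained, but its gap to compound 1 lies within the usual scatter, so the two cannot be told apart. One value of the three stands at the limit, (the limit of > 1000000 nM in this assay, at which 1 of the 3 values shown sits), which leaves only compound 1 and compound 3 as measured numbers.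

Compound 4 `CCc1cncc(OC[C@@H]2CCCN2C)c1` is reached from compound 3 by one change: ethyl in place of bromo on an aromatic carbon. Within the data shown here, no measured pair in this set isolates such a change, so the step from compound 3 to compound 4 is expected to be small, a 1.3-fold higher number from compound 3 to compound 4 (0.13 log units; within the scatter), with neither direction favoured beyond the scatter. Compound 4 is therefore estimated to give 8000 nM in this assay, within a range from 2000 nM to 32000 nM.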

Compound 4, half-maximal effective concentration: 1000 nM
Compound 4: the middle estimate sits 8.0-fold (0.90 log units) above what was measured, outside the stated range (below it).
By their numbers in this assay, from the lowest: compound 4; then compounds 1 and 3 (each within the scatter of the next). At a limit, above all of these: compound 2.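

In this assay, the aromatic carbon two atoms from the ring nitrogen proves sensitive to what it carries: ethyl in place of bromo gives a 6.0-fold lower number from compound 3 to compound 4 (0.77 log units; beyond the scatter) and lies beyond the scatter. Among these compounds, the earlier compounds offered no step that could be read, so this is the first evidence in the set that a single change on the shared core can move the number. Neither group carries a ring, a hydrogen-bond donor, a hydrogen-bond acceptor or a net charge, so the step comes with no change in any of these counted features, and less compound is needed for the effect with ethyl on this carbon than with bromo.

On these data alone, it remains open whether a longer chain such as propyl, an amine or a carboxylic acid on this same carbon would take the number further down or bring it back up, and whether ethyl would have the same effect elsewhere on the ring. No measurement shown gives a reason for the direction or the size of this step.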